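Cyano to hydroxymethyl on compound 2

A few compounds are considered here, and "the series" means these few. Any claim that something is new, unique, unknown or untested is made for them only; others in the source may bear on it.

Measured so far in an ADME assay on HeLa Rh cells (Homo sapiens) for cytotoxicity, read by microscopy; a higher number here means that more compound is tolerated, a lower number that less compound is tolerated
compound 1 `COc1cc(CC(O)c2ccc(-c3cccc(Cl)c3)cc2)c([N+](=O)[O-])cc1OC` with 5900 nM
compound 2 `COc1cc(CC(O)c2ccc(-c3ccccc3C#N)cc2)c([N+](=O)[O-])cc1OC` with 9300 nM

For the measured compounds named here, compound 2 at 9300 nM lies within the scatter of compound 1, the only other measured compound. Compound 3 `COc1cc(CC(O)c2ccc(-c3ccccc3CO)cc2)c([N+](=O)[O-])cc1OC` has hydroxymethyl in place of cyano on an aromatic carbon, ortho to a large group (hydroxymethyl in place of cyano on an aromatic carbon). Going by the values given here, one measured step bears on this change, namely a 1.6-fold higher number from compound 1 to compound 2 (0.20 log units; within the scatter) and it swaps the whole 3-chlorophenyl for 2-cyanophenyl. It is a small step, but it is not the same replacement. Among the compounds with values here, no measured compound carries hydroxymethyl, so the data give no direction for this change. In this assay no step beyond the scatter is therefore expected, and neither direction is favoured. The estimated step is a 1.2-fold lower number from compound 2 to compound 3 (0.07 log units; within the scatter) and it stays within that expectation. Compound 3 is expected at 8000 nM with an estimated range from 3500 nM to 18000 nM in this assay.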

Compound 3, half-maximal cytotoxic concentration: 24000 nM
The estimate for compound 3 lay 3.0-fold (0.48 log units) below the measured number; the whole stated range lies below it.
By their numbers in this assay, from the lowest: compounds 1 and 2 (each within the scatter of the next); then compound 3.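

In this assay, for the compounds shown here, hydroxymethyl in place of cyano on this aromatic carbon, ortho to a large group, gives a 2.6-fold higher number from compound 2 to compound 3 (0.41 log units; beyond the scatter) and is the first step to lie beyond the scatter. Against the 3-chlorophenyl of compound 1, the 2-(hydroxymethyl)phenyl gives a 4.1-fold higher number from compound 1 to compound 3 (0.61 log units; beyond the scatter) and so places compound 3 above both other compounds, while compounds 1 and 2 stay within the scatter of each other. This place on the ring therefore does respond to the choice of group in this assay, and the change that does so keeps the count of heavy atoms and brings in a hydrogen-bond donor where cyano has none, though that difference is a description of the pair and not an explanation.

Still open, from the compounds shown here alone, is whether the higher number depends on the free hydroxyl or would also appear with methoxymethyl, aminomethyl or a carboxylic acid at the same place. A longer chain such as 2-hydroxyethyl would show whether the step holds once the hydroxyl is carried further out. No measurement at hand gives a reason for this step.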